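Methoxy pattern on the aniline and cytotoxicity

A few compounds are considered here, and "the series" means these few. Any claim that something is new, unique, unknown or untested is made for them only; others in the source may bear on it.

Measured so far:
compound 1 `COc1ccc(N/C(CCNC2=CC(=O)c3ccccc3C2=O)=N\S(=O)(=O)c2ccc(C)cc2)cc1`: 25500 nM
compound 2 `COc1ccc(N/C(CCNC2=CC(=O)c3ccccc3C2=O)=N\S(=O)(=O)c2ccc(C)cc2)c(OC)c1`: 126000 nM

In a functional assay on A549 cells (Homo sapiens) for cytotoxicity, read by MTT assay, with a stated time of 48 h (a higher number here means a weaker inhibitor, a lower number a stronger inhibitor), compound 1 gives 25500 nM and compound 2 gives 126000 nM. Compound 2 carries the highest number of the two measured, its nearest neighbour being compound 1 with the step of a 4.9-fold higher number from compound 1 to compound 2 (0.69 log units; beyond the scatter). Compound 3 `COc1cc(N/C(CCNC2=CC(=O)c3ccccc3C2=O)=N\S(=O)(=O)c2ccc(C)cc2)cc(OC)c1OC` differs from compound 2 by 3,4,5-trimethoxyphenyl in place of 2,4-dimethoxyphenyl on an amine nitrogen. Among the measured compounds shown here, the only step that bears on this change is a 4.9-fold higher number from compound 1 to compound 2 (0.69 log units; beyond the scatter), a modest rise on adding methoxy, so in this assay a further rise or a step within the scatter is expected. Compound 3 is expected to give 150000 nM (range 50000 nM to 400000 nM), an expected step of a 1.2-fold higher number from compound 2 to compound 3 (0.08 log units; within the scatter).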

Compound 3, half-maximal inhibitory concentration: 7940 nM
The estimate for compound 3 lay 19-fold (1.28 log units) above the measured number; the whole stated range lies above it.
By their numbers in this assay, from the lowest: compound 3; then compound 1; then compound 2.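

In this assay the aryl group on the amine nitrogen does not move one way as methoxy groups are added: a 16-fold lower number from compound 2 to compound 3 (1.20 log units; beyond the scatter) follows 3,4,5-trimethoxyphenyl replacing 2,4-dimethoxyphenyl, and a 3.2-fold lower number from compound 1 to compound 3 (0.51 log units; beyond the scatter) follows the same group replacing 4-methoxyphenyl. Compound 2 therefore stands against any trend toward lower numbers with more methoxy, and compound 3 against any trend toward higher ones. Nothing available accounts for this reversal.

Compounds 2 and 3 differ in both methoxy number and placement, so the two remain unseparated. An unsubstituted phenyl or a 3,5-dimethoxyphenyl group would bear on this question.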